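Varying the Side Chain on the Shared Core of Compound 2

The source may hold more compounds than are shown below. What is called first, only, known or untested is meant among the compounds shown, and "the series" means these compounds.

Measured so far:
compound 1, `Cc1ccccc1Cc1cnc(CCc2ccc(-c3ccccc3C(=O)O)cc2)[nH]1`, 127 nM;
compound 2, `O=C(O)c1ccccc1-c1ccc(CCc2ncc(CC3CCCC3)[nH]2)cc1`, 133 nM;
compound 3, `CC(C)CCc1cnc(CCc2ccc(-c3ccccc3C(=O)O)cc2)[nH]1`, 119 nM.

In an in vitro functional assay on cells for agonist activity at Bombesin receptor subtype-3 (Homo sapiens), read by luminescence and calcium flux (a lower number here means that less compound is needed, a higher number that more compound is needed for the effect), compound 2 sits alongside the other two: the step of a 1.0-fold higher number from compound 1 to compound 2 (0.02 log units; within the scatter) and the step of a 1.1-fold lower number from compound 2 to compound 3 (0.05 log units; within the scatter) both lie within the scatter, as does a 1.1-fold lower number from compound 1 to compound 3 (0.03 log units; within the scatter). Compound 4, `CCC(C)(CC)Cc1cnc(CCc2ccc(-c3ccccc3C(=O)O)cc2)[nH]1`, differs from compound 2 by 1-ethyl-1-methylpropyl in place of cyclopentyl on a saturated chain carbon bound to an aromatic carbon. The three earlier steps all alter this same position and none moves the number beyond the scatter, so for compound 4 the step of a 1.1-fold higher number from compound 2 to compound 4 (0.02 log units; within the scatter) is expected to stay within the scatter as well. Compound 4 is therefore estimated at 140 nM, with a range from 60 nM to 330 nM.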

Compound 4, half-maximal effective concentration: 76 nM
For compound 4 the middle estimate is 1.8-fold (0.27 log units) above the measured one; low and high end bracket the measured number.
By their numbers in this assay, from the lowest: compounds 4, 3, 1 and 2 (each within the scatter of the next).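

In this assay, 1-ethyl-1-methylpropyl stays within the scatter of all three earlier groups on a saturated chain carbon bound to an aromatic carbon: a 1.8-fold lower number from compound 2 to compound 4 (0.24 log units; within the scatter), a 1.6-fold lower number from compound 3 to compound 4 (0.19 log units; within the scatter) and a 1.7-fold lower number from compound 1 to compound 4 (0.22 log units; within the scatter). Within the data shown here, these steps are larger than any seen among the earlier compounds, yet none leaves the scatter, so the position holds this group as it holds cyclopentyl, isobutyl and 2-methylphenyl. No evidence is available that bears on these steps.

Going by these compounds, all four groups contain only carbon, so it stays open whether an amine, a hydroxyl or a carboxylic acid at this position would keep the number within the scatter.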